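Swapping Trifluoromethyl for Bromo on a Biaryl Amide

The source may report more compounds than this note shows. Statements on the series, on what has been measured and on what is new or still open speak of the compounds shown alone.

Compound 1 `CCOC(=O)CCCCCOc1cccc(CN(C(=O)c2ccc(-c3ccco3)cc2)C(C)C)c1`: in an ADME assay on HEK293 cells (Homo sapiens) for cytotoxicity, read by CellTiter-Glo and resazurin assay, with a stated time of 72 h (on this read-out lower numbers stand for an effect already at smaller amounts and higher numbers for an effect only at larger amounts of compound), compound 1 gives > 26000 nM, which is a limit of the assay and not a number.
Compound 2 `CCOC(=O)CCCCCOc1cccc(CN(C(=O)c2ccc(-c3cccc(OCc4ccccc4)c3)cc2)C(C)C)c1`: in this assay compound 2 gives > 26000 nM, again a limit.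
Compound 3 `CCOC(=O)CCCCCOc1cccc(CN(C(=O)c2ccc(-c3cccc(C(F)(F)F)c3)cc2)C(C)C)c1`: in this assay compound 3 gives > 26000 nM, also a limit.

All three compounds share one core and differ only in the group on the outer aromatic ring. Compound 3 therefore stands on no fixed number; it sits at the limit of > 26000 nM in this assay, at which 3 of the 3 values shown sit, together with the other two compounds.

Compound 4 `CCOC(=O)CCCCCOc1cccc(CN(C(=O)c2ccc(-c3cccc(Br)c3)cc2)C(C)C)c1` differs from compound 3 by a single exchange: bromo in place of trifluoromethyl on an aromatic carbon.

Two measured steps lead into compound 3, the change from furan-2-yl in a step that the two limits leave unreadable from compound 1 to compound 3 and the change from benzyloxy in a step that the two limits leave unreadable from compound 2 to compound 3. Neither step can be sized, since both ends rest on a limit. Nothing in these numbers points to a change beyond the scatter, so the step is expected to be a step that the limit leaves unreadable from compound 3 to compound 4. Compound 4 is therefore expected to give 30000 nM in this assay, within 10000 nM to 100000 nM, most probably again reported only as a limit.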

Compound 4, half-maximal effective concentration: > 26000 nM
Compound 4 ended at the assay's limit; the forecaster's own chance of this, stated with the estimate: 85%; the middle value does not contradict the limit.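

Within the data shown here, no step between compound 1, compound 2, compound 3 and compound 4 can be read in this assay, because each value is a limit of the assay and not a number: the limit of > 26000 nM in this assay, at which 4 of the 4 values shown sit. The compounds shown leave open how far apart these four compounds truly lie, and at what amount each would begin to show an effect.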